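The source may report more compounds than this note shows. Statements on the series, on what has been measured and on what is new or still open speak of the compounds shown alone.

Measured in a functional assay on SEM cells (Homo sapiens) for cytotoxicity, with a stated time of 72 h; on this read-out lower numbers stand for an effect already at smaller amounts and higher numbers for an effect only at larger amounts of compound:
- compound 1 `C=C[C@@](C)(/C=C/c1ccc(O)cc1)CC/C=C(C)/C=C/C(=O)OCc1ccccc1`: > 36600 nM (a limit of the assay)
- compound 2 `C=C[C@@](C)(/C=C/c1ccc(O)c(/C=C/C#N)c1)CCC=C(C)C`: > 36600 nM (a limit of the assay)
- compound 3 `COc1ccc(/C=C/[C@@](C)(/C=C/c2ccc(O)c(/C=C/C#N)c2)CCC=C(C)C)cc1`: 4540 nM

Among these, compound 3 is the only one with a true number, 4540 nM. The other two compounds stop at the limit of > 36600 nM in this assay, at which 2 of the 3 values shown sit, so no exact comparison with them is possible.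

Compound 4 `COc1ccc(/C=C/[C@@](C)(/C=C/c2ccc(O)c(/C=C/C(=O)OC(C)(C)C)c2)CCC=C(C)C)cc1` has not yet been measured. It differs from compound 3 by tert-butoxycarbonyl in place of cyano on a double-bonded chain carbon bound to a double-bonded chain carbon. Put simply, this is tert-butoxycarbonyl in place of cyano on a double-bonded chain carbon bound to a double-bonded chain carbon.

Among the compounds with values here, only one measured step is available, an at least 8.0-fold lower number from compound 2 to compound 3 (0.90 log units; beyond the scatter). It brings in 2-(4-methoxyphenyl)ethenyl in place of vinyl and lies beyond the scatter. However, that step concerns a different place in the molecule, so it gives no direct guide to the size of this change. Compound 1 also carries an ester, but it differs from compound 3 in too many places to help. Within the data shown here, with no measured step at this place, no change beyond the scatter is expected, although the uncertainty is wide.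

The expected outcome is a 1.3-fold higher number from compound 3 to compound 4 (0.12 log units; within the scatter). For compound 4 the estimated value is 6000 nM, with an expected range from 1800 nM to 30000 nM.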

Compound 4, half-maximal effective concentration: > 36600 nM
Compound 4 gave a limit, no number (the forecaster's own chance of this, stated with the estimate: 25%); middle value at least 6.1-fold (0.78 log units) from the limit.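

Swapping cyano for tert-butoxycarbonyl on a double-bonded chain carbon bound to a double-bonded chain carbon gives an at least 8.0-fold higher number from compound 3 to compound 4 (0.90 log units; beyond the scatter) in this assay, so this position is not indifferent to the group it carries. Within the data shown here, until now, the only measured step came from the other side of the molecule, an at least 8.0-fold lower number from compound 2 to compound 3 (0.90 log units; beyond the scatter), where 2-(4-methoxyphenyl)ethenyl replaced vinyl; among compounds 2, 3 and 4, the value of compound 3 is now the only true number, and a single change in either of these two places leads back to the limit. The value of compound 4 is only a limit, so the step has a floor but no exact size: the limit of > 36600 nM in this assay, at which 3 of the 4 values shown sit.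

Going by these compounds, what remains open is whether the result goes with the larger size of tert-butoxycarbonyl or with replacing the nitrile by an ester. A methyl ester, a carboxylic acid or a primary amide on the same carbon would help separate these two readings, and it would also show whether any group other than cyano gives a true number here.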